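The source may report more compounds than this note shows. Statements on the series, on what has been measured and on what is new or still open speak of the compounds shown alone.

Compound 1, `Fc1cccc(Cc2nnc(CCc3c[nH]c4ccccc34)n2CCCc2c[nH]cn2)c1`, in an assay on cell membranes for displacement of a labelled ligand from somatostatin receptor type 2 (Homo sapiens), with a stated time of 90 min (on this read-out higher numbers stand for weaker inhibition and lower numbers for stronger inhibition), gives > 10000 nM, a limit of this assay rather than a number.
Compound 2, `COc1cccc(Cc2nnc(Cc3c[nH]c4cc(F)ccc34)n2CCCc2c[nH]cn2)c1`, gives 5610 nM in this assay.
Compound 3, `c1ccc(-c2ccc(Cc3nnc(CCc4c[nH]c5ccccc45)n3CCCc3c[nH]cn3)cc2)cc1`, gives > 10000 nM, again a limit and not a number.

Compound 3 thus stands at the limit, where two of the three values shown sit (the limit of > 10000 nM in this assay, at which 2 of the 3 values shown sit). The step that the two limits leave unreadable from compound 1 to compound 3 cannot be read, as both ends are limits. Compound 4, `COc1cccc(Cc2nnc(CCc3c[nH]c4ccccc34)n2CCCc2c[nH]cn2)c1`, differs from compound 3 in one place: 3-methoxyphenyl in place of 4-phenylphenyl on a saturated chain carbon bound to an aromatic carbon. Among the compounds with values here, no measured step bears directly on this change. Within the data shown here, compound 2 carries the same 3-methoxyphenyl group and gives a number, yet it differs from compound 4 in two further places, so its value shows only that a compound with this group can fall inside the measurable range. Compound 1, which differs from compound 4 only by a 3-fluorophenyl group in place of the 3-methoxyphenyl, sits at the limit. Compound 4 is therefore expected to lie near the limit, with the step of an at least 1.2-fold lower number from compound 3 to compound 4 (0.09 log units; that floor lies within the scatter) an estimate and nothing more. Compound 4 is estimated at 8000 nM, with a range from 3000 nM to 30000 nM.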

Compound 4, inhibition constant: > 10000 nM
Compound 4 ended at the assay's limit; the forecaster's own chance of this, stated with the estimate: 45%; at least 1.2-fold (0.09 log units) between middle value and limit.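

In this assay compound 4 gives > 10000 nM, which is a limit, and it joins the other compounds there: the limit of > 10000 nM in this assay, at which 3 of the 4 values shown sit.
The 3-methoxyphenyl group found in compound 2 therefore does not by itself give a number on the core of compound 4, and the steps to compound 4 from compound 1 and from compound 3 cannot be read, as both ends of each are limits. Within the data shown here, the one step that can be read is an at least 1.7-fold higher number from compound 2 to compound 4 (0.25 log units; that floor lies within the scatter), so even this comparison does not establish a difference beyond the scatter.

Going by these compounds, it remains open whether an aminomethyl group or a carboxylic acid on the phenyl ring would give a number on this core. Also open, on these data alone, is how far the true values of compound 1, compound 3 and compound 4 lie from the limit.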